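Aryl ether variation on the piperidine-triazine series

A few compounds are considered here, and "the series" means these few. Any claim that something is new, unique, unknown or untested is made for them only; others in the source may bear on it.

Among the compounds with values here, compound 1 `Brc1ccccc1OC1CCN(c2ccc(-n3ccnc3)nn2)CC1` sits second highest of the three numbers so far: in an assay on microsomes from liver for inhibition of acyl-CoA desaturase 1 (Rattus norvegicus) (a lower number here means a stronger inhibitor, a higher number a weaker inhibitor), compound 1 gives 5 nM. Compound 2 `OCc1nnc(-c2ccc(N3CCC(Oc4ccccc4C(F)(F)F)CC3)nn2)s1` gives 3.2 nM in this assay, a gap from compound 1 that lies within the scatter. Compound 3 `CC(C)Cc1nnc(-c2ccc(N3CCC(Oc4ccccc4C(F)(F)F)CC3)nn2)s1` gives 37 nM, beyond the scatter from compound 1. Within the data shown here, the only measured step, a 12-fold higher number from compound 2 to compound 3 (1.06 log units; beyond the scatter), concerns the substituent on the thiadiazole and not the aryl ether, so no measured step bears on the change to compound 4 `c1cc(OC2CCN(c3ccc(-n4ccnc4)nn3)CC2)c2cc[nH]c2c1`, which is 1H-indol-4-yl in place of 2-bromophenyl on an oxygen on a saturated carbon. Among the measured compounds shown here, with no directly comparable step, the expectation is a small shift, a 2.4-fold higher number from compound 1 to compound 4 (0.38 log units; beyond the scatter), in either direction. Compound 4 is therefore estimated at 12 nM, within 3 nM to 50 nM.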

Compound 4, half-maximal inhibitory concentration: 162 nM
Compound 4: middle estimate off by 14-fold (1.13 log units), on the low side; measured number outside the range, above it.
By their numbers in this assay, from the lowest: compounds 2 and 1 (each within the scatter of the next); then compound 3; then compound 4.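

In this assay, within the data shown here, the group on the oxygen proves sensitive: 1H-indol-4-yl in place of 2-bromophenyl gives a 32-fold higher number from compound 1 to compound 4 (1.51 log units; beyond the scatter), the first measured step at this position. The change removes the bromine and adds a five-membered aromatic ring and a hydrogen-bond donor at once, so this single step cannot separate those features. No measurement bears on the reason for the step.

Whether the bromine or the indole accounts for the step remains open. Plain phenyl, 2-chlorophenyl or 1H-indol-5-yl on the core of compound 1 would bear on that question.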